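Replacing an Anilino Group with Azetidin-1-yl

The source may report more compounds than this note shows. Statements on the series, on what has been measured and on what is new or still open speak of the compounds shown alone.

Measured in a functional assay on MCF7 cells (Homo sapiens) for inhibition, read by sulforhodamine B assay; on this read-out lower numbers stand for stronger inhibition and higher numbers for weaker inhibition:
Compound 1 `Cc1ccc(NC2=CC(=O)c3c(nc4n3[C@H]3OC[C@@H](O)[C@H]3OC4)C2=O)cc1C` gives 4950 nM.
Compound 2 `O=C1C=C(Nc2ccccc2)C(=O)c2c1nc1n2[C@H]2OC[C@@H](O)[C@H]2OC1` gives > 4000 nM, which is a limit of the assay and not a number.
Compound 3 `O=C1C(NC2CCCC2)=CC(=O)c2c1nc1n2[C@H]2OC[C@@H](O)[C@H]2OC1` gives > 16000 nM, also a limit of the assay rather than a number.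

Compound 2 therefore has no fixed place among the numbers shown: its result is the limit of > 4000 nM in this assay, at which 1 of the 3 values shown sits, and the only true number belongs to compound 1. Compound 3 sits at the limit of > 16000 nM in this assay, at which 1 of the 3 values shown sits.

The unmeasured compound 4 `O=C1C=C(N2CCC2)C(=O)c2c1nc1n2[C@H]2OC[C@@H](O)[C@H]2OC1` differs from compound 2 by azetidin-1-yl in place of anilino on a double-bonded ring carbon. Among the measured compounds shown here, this is a change from an aromatic amine substituent to a saturated ring amine, and the one measured step of that kind is an at least 3.2-fold higher number from compound 1 to compound 3 (0.50 log units; beyond the scatter), where the saturated ring gave the weaker result. On that basis a step in the same direction is expected here, toward weaker inhibition, though only the direction and a rough size can be read from a single step that itself ends at a limit.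

For compound 4 the expected result in this assay is 20000 nM, with a range from 6000 nM to 60000 nM, and the assay may well report only a limit. The expected step is a step that the limit leaves unreadable from compound 2 to compound 4.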

Compound 4, half-maximal inhibitory concentration: > 16000 nM
Compound 4: only a limit was reported; the forecaster's own chance of this, stated with the estimate: 70%; the middle value is on the limit's open side.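

Compound 4 gives > 16000 nM, which is a limit of the assay and not a number. Compound 2 gives > 4000 nM, also a limit. With only these two limits, no step can be read between compound 2 and compound 4. The compounds shown leave open whether azetidin-1-yl in place of anilino changes the result in this assay, and by how much.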